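This account rests on a few compounds, and the source may have more. Where it says the series, first, only, none or still open, it means among the compounds named here.

Three analogues of a shared core have been measured in a functional assay on the whole organism (plasma, strain albino) for inhibition, with Rattus norvegicus as the target, with stated times of 1 h and 4 h, at a dose of 50 mg/kg by the oral route; a lower number here means a weaker effect, a higher number a stronger effect of the compound at the dose given. Compound 1 `COc1ccc(Cl)cc1C(=O)Nc1ccc(C2=NN(C)C(c3ccc([N+](=O)[O-])cc3)C2)cc1` gives 83.2% in this assay. Compound 2 `COc1ccc(C2CC(c3ccc(NC(=O)c4cc(Cl)ccc4OC)cc3)=NN2)cc1` gives 83% in this assay. Compound 3 `COc1ccc(Cl)cc1C(=O)Nc1ccc(C2=NNC(c3ccccc3[N+](=O)[O-])C2)cc1` gives 84.5% in this assay. Compound 3 thus holds the highest number of the three, yet its gap to compound 1 and its gap to compound 2 each lie within the scatter, so the three compounds are not separated by these numbers.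

The next member is compound 4 `COc1ccc(Cl)cc1C(=O)Nc1ccc(C2=NNC(c3ccc([N+](=O)[O-])cc3)C2)cc1`, which differs from compound 3 only in the group on the saturated ring carbon: 4-nitrophenyl in place of 2-nitrophenyl on a saturated ring carbon.

Going by the values given here, one measured step concerns that same saturated ring carbon: a number 1.5 percentage points higher from compound 2 to compound 3 (within the scatter). An exchange of the aryl group at that carbon therefore left the read-out in this assay unchanged beyond the scatter. Among the compounds with values here, compound 1 also carries the 4-nitrophenyl group that enters, and compound 1 gives 83.2%, a number within the scatter of compound 3; no single step links compound 1 to compound 4, so only the two values are set side by side. For the move from compound 3 to compound 4 no step beyond the scatter is expected in this assay, and a number 1 percentage points lower from compound 3 to compound 4 (within the scatter) is the expected change. Compound 4 is estimated at 83.5%, with a range from 76% to 90%.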

Compound 4, a percentage reported as inhibition, in the whole organism at one dose (the size of the read-out at that dose, not a potency): 86.3%
Compound 4: middle estimate off by 2.8 percentage points, on the low side, within the range that was stated.
By their numbers in this assay, from the lowest: compounds 2, 1, 3 and 4 (each within the scatter of the next).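

In this assay, the nitro group changes place on the phenyl ring while the atoms stay the same, and this isomer pair is not separated (a number 1.8 percentage points higher from compound 3 to compound 4 (within the scatter)), so the placement of the nitro group on this aryl group at the saturated ring carbon does not register in this read-out. The two other single exchanges that reach compound 4 are also unresolved: nitro in place of methoxy on an aromatic carbon (a number 3.3 percentage points higher from compound 2 to compound 4 (within the scatter)) and hydrogen in place of methyl on an amine nitrogen in a ring (a number 3.1 percentage points higher from compound 1 to compound 4 (within the scatter)). No independent data bear on why these exchanges leave the read-out flat.

The compounds shown leave open whether this assay, at its single dose, can separate any change at this carbon, since every compound lies within the scatter of its neighbour in the order of values. Also open, going by these compounds, is whether the aryl group is needed at all, which a plain methyl or hydrogen on the saturated ring carbon would test, while an amine or a carboxylic acid on the phenyl ring in place of nitro would extend the range of groups.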